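The source may hold more compounds than are shown below. What is called first, only, known or untested is meant among the compounds shown, and "the series" means these compounds.

In an in vitro ADME assay on microsomes (Rattus norvegicus) for metabolic stability (on this read-out higher numbers stand for a longer-lived compound and lower numbers for a shorter-lived compound), three compounds have been measured so far. Compound 1 (`Cc1c2c(n3c1CCN(C(=O)[C@H](C)N)CC[C@H](C)Nc1cc-3ccc1C(N)=O)CC(C)(C)CC2=O`) gives > 0.5 h, which is a limit of the assay and not a number. Compound 2 (`CC(=O)N1CCc2c(C)c3c(n2-c2ccc(C(N)=O)c(c2)N[C@@H](C)[C@H](C)C1)CC(C)(C)CC3=O`) gives 0.333 h. Compound 3 (`Cc1c2c(n3c1CCN(C(=O)CN)C[C@@H](C)[C@H](C)Nc1cc-3ccc1C(N)=O)CC(C)(C)CC2=O`) gives > 0.5 h, again a limit and not a number. Compound 3 therefore stands at the limit of > 0.5 h in this assay, at which 2 of the 3 values shown sit, and its true half-life is not known.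

Among the measured compounds shown here, the one measured step between these compounds is an at least 1.5-fold higher number from compound 2 to compound 3 (0.17 log units; that floor lies within the scatter). It comes from amino in place of hydrogen on a saturated chain carbon bound to a carbonyl carbon. On these data alone, since only its floor is known, its full size remains open.

Compound 4 (`CC[C@H](N)C(=O)N1CCc2c(C)c3c(n2-c2ccc(C(N)=O)c(c2)N[C@@H](C)[C@H](C)C1)CC(C)(C)CC3=O`) differs from compound 3 by ethyl in place of hydrogen on a saturated chain carbon bound to an amine nitrogen and a carbonyl carbon. For the measured compounds named here, no measured step tests this exchange, so the step from amino to hydrogen offers only a loose guide.

The expectation rests mainly on compound 3 at > 0.5 h, a limit, and no change beyond the scatter is expected in this assay. The estimated step is a step that the limit leaves unreadable from compound 3 to compound 4. For compound 4 the estimated half-life is 0.6 h, with an expected range from 0.3 h to 1.2 h.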

Compound 4, half-life: > 0.5 h
Compound 4: no number, only a limit; the forecaster's own chance of this, stated with the estimate: 65%; the middle value lies beyond the limit too.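

In this assay compound 4 gives > 0.5 h, which is a limit of the assay and not a number. On these data alone, putting 1-aminopropyl in place of methyl on the carbonyl carbon gives an at least 1.5-fold higher number from compound 2 to compound 4 (0.17 log units; that floor lies within the scatter), so a second amine-bearing group at this carbonyl reaches the same limit, although the size of the step stays open and its floor alone does not separate it from the scatter. The step from aminomethyl to 1-aminopropyl cannot be read, since the values at both of its ends are limits, but ethyl on the saturated chain carbon bound to an amine nitrogen and a carbonyl carbon does not bring the half-life down to a readable number, and more of the series now shares one limit: the limit of > 0.5 h in this assay, at which 3 of the 4 values shown sit.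

As far as these compounds go, how far compound 3 and compound 4 each lie past the limit stays unknown, so any gain or loss from the ethyl remains hidden. Also open, from the compounds shown here alone, is whether a longer chain such as butyl on this carbon, or a carboxylic acid in place of the amine, would stay at this limit or give a readable half-life in this assay.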